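Half-life from compound 2 to compound 3

The source may hold more compounds than are shown below. What is called first, only, known or untested is meant among the compounds shown, and "the series" means these compounds.

Compound 1 `COc1cc2c(Oc3ccc(Nc4nccc5[nH]cc(-c6ccc(F)cc6)c(=O)c45)cc3F)ccnc2cc1OCCO`: 1.48 h
Compound 2 `O=c1c(-c2ccc(F)cc2)c[nH]c2ccnc(Nc3ccc(Oc4ccnc5cc(OCCO)ccc45)c(F)c3)c12`: 1.51 h

In an ADME assay on microsomes from liver (Rattus norvegicus) for metabolic stability (a lower number here means that the compound disappears faster, a higher number that the compound lasts longer), compound 2 gives 1.51 h, which lies within the scatter of compound 1, so neither ranks above the other. Compound 3 `CC(C)(O)COc1ccc2c(Oc3ccc(Nc4nccc5[nH]cc(-c6ccc(F)cc6)c(=O)c45)cc3F)ccnc2c1` differs from compound 2 by 1-hydroxy-1-methylethyl in place of hydroxymethyl on a saturated chain carbon bound to an oxygen on an aromatic ring. Going by the values given here, the only measured step, a 1.0-fold higher number from compound 1 to compound 2 (0.01 log units; within the scatter), stays within the scatter. That step is hydrogen in place of methoxy on an aromatic carbon, a different change, so it bears on this one only loosely. Among the compounds with values here, no measured step tests the new chain, so nothing supports a large shift in either direction. The expected step is a 1.2-fold higher number from compound 2 to compound 3 (0.08 log units; within the scatter), which would not go beyond the scatter. Compound 3 is estimated at 1.8 h, with an expected range of 0.9 h to 3.6 h.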

Compound 3, half-life: 4.14 h
Compound 3: the middle estimate sits 2.3-fold (0.36 log units) below what was measured; measured number outside the range, above it.
By their numbers in this assay, from the lowest: compounds 1 and 2 (each within the scatter of the next); then compound 3.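

In this assay the side chain on the oxygen proves to be a place where the number can move: replacing hydroxymethyl with 1-hydroxy-1-methylethyl on the saturated chain carbon gives a 2.7-fold higher number from compound 2 to compound 3 (0.44 log units; beyond the scatter). Going by these compounds alone, the earlier change, hydrogen in place of methoxy on an aromatic carbon, gave only a 1.0-fold higher number from compound 1 to compound 2 (0.01 log units; within the scatter), so this is the first step to clear the scatter, though its size is modest. Nothing measured here explains the rise.

A single pair cannot say whether the rise depends on the hydroxyl group or on the larger chain end, or whether it would also appear with the methoxy group of compound 1 in place. Nor do these compounds show how a longer chain, an amine or a carboxylic acid would fare at this position.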